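Lengthening the chain to the piperidine ring

This account rests on a few compounds, and the source may have more. Where it says the series, first, only, none or still open, it means among the compounds named here.

Compound 1 `COc1ccc(Br)cc1CCc1c(F)cccc1C(=O)/N=C(\N)NCCN1CCCC1`: 4500 nM
Compound 2 `COc1ccc(Br)cc1CCc1c(F)cccc1C(=O)/N=C(\N)NCCC1CCCCC1`: "not determined" (no result reported)
Compound 3 `COc1ccc(Br)cc1CCc1c(F)cccc1C(=O)/N=C(\N)NCCCN1CCCCC1`: 330 nM

In a functional assay for antagonist activity at Melanocortin receptor 4 (Homo sapiens), read by cAMP accumulation (on this read-out higher numbers stand for weaker inhibition and lower numbers for stronger inhibition), compound 3 gives 330 nM and stands lowest among the numbers shown. Among the compounds with values here, its only measured neighbour with a number is compound 1, which gives 4500 nM; the step between them is a 14-fold lower number from compound 1 to compound 3 (1.13 log units; beyond the scatter). Compound 2 has no reported result, so it offers no comparison.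

Compound 4 `COc1ccc(Br)cc1CCc1c(F)cccc1C(=O)/N=C(\N)NCCCCN1CCCCC1` is not yet measured. It differs from compound 3 by (piperidin-1-yl)methyl in place of piperidin-1-yl on a saturated chain carbon, three bonds along the chain from an amine nitrogen. Within the data shown here, the only measured step, from compound 1 to compound 3, changes both the ring and the chain at once, so it does not isolate the effect of one additional chain carbon. It shows only that this part of the molecule can move the number strongly. Among the measured compounds shown here, with no direct precedent, the expectation for compound 4 is a step of a 1.2-fold higher number from compound 3 to compound 4 (0.08 log units; within the scatter), that is, no change beyond the scatter, but with wide uncertainty in either direction. Compound 4 is therefore estimated at 400 nM, within a range from 120 nM to 1500 nM.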

Compound 4, half-maximal inhibitory concentration: 70 nM
Compound 4: middle estimate off by 5.7-fold (0.76 log units), on the high side; the whole stated range lies above it.
By their numbers in this assay, from the lowest: compound 4; then compound 3; then compound 1.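

In this assay, adding chain length while keeping the piperidine ring gives a 4.7-fold lower number from compound 3 to compound 4 (0.67 log units; beyond the scatter), so chain length alone moves the number here, which the earlier pair, with ring and chain changed together, could not show. Over the wider change of ring and chain together, the step is a 64-fold lower number from compound 1 to compound 4 (1.81 log units; beyond the scatter), and across compound 1, compound 3 and compound 4 the number falls each time the chain grows, with no measured compound going against this. No measurement here explains why the longer chain goes with the lower number.

A still longer chain ending in piperidin-1-yl could lower the number further or raise it again. Pyrrolidin-1-yl or an open-chain amine such as diethylamino on the chain of compound 4 would show how much depends on the ring itself.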